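Exchanging bromo for chloro on compound 2

A few compounds are considered here, and "the series" means these few. Any claim that something is new, unique, unknown or untested is made for them only; others in the source may bear on it.

Three compounds have values in an ADME assay on Vero cells (Chlorocebus sabaeus) for cytotoxicity, read by resazurin assay, with a stated time of 72 h (a higher number here means a weaker inhibitor, a lower number a stronger inhibitor), so far:

- Compound 1 `O=C(CCN1CCN(c2ccc(F)cc2)CC1)c1ccc(F)c(Br)c1` gives 352000 nM
- Compound 2 `O=C(CCN1CCN(c2ccc(Cl)cc2)CC1)c1ccc(F)c(Br)c1` gives 206000 nM
- Compound 3 `O=C(CCN1CCN(c2ccc([N+](=O)[O-])cc2)CC1)c1ccc(F)c(Br)c1` gives 256000 nM

Compound 2 lies within the scatter of both compound 1 and compound 3, so the three values cannot be ranked. The next compound is compound 4 `O=C(CCN1CCN(c2ccc(Cl)cc2)CC1)c1ccc(F)c(Cl)c1` and its difference from compound 2 is chloro in place of bromo on an aromatic carbon in a single exchange, chloro in place of bromo on an aromatic carbon. The 3-bromo-4-fluorophenyl thus becomes 3-chloro-4-fluorophenyl.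

Among the compounds with values here, no measured step touches the bromo group. The available steps exchange fluoro, chloro and nitro elsewhere in the molecule, and they are small: a 1.7-fold lower number from compound 1 to compound 2 (0.23 log units; within the scatter) and a 1.4-fold lower number from compound 1 to compound 3 (0.14 log units; within the scatter) and also a 1.2-fold higher number from compound 2 to compound 3 (0.09 log units; within the scatter) in the same series. Within the data shown here, with only these as a guide, no step beyond the scatter is expected in this assay for this exchange, although no measured pair tests it directly. The estimate means a 1.1-fold higher number from compound 2 to compound 4 (0.03 log units; within the scatter) and so an expected change within the scatter. For compound 4 the estimated value is 220000 nM with an expected range from 110000 nM to 420000 nM in this measurement.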

Compound 4, half-maximal inhibitory concentration: 114000 nM
Compound 4: middle estimate off by 1.9-fold (0.29 log units), on the high side; the measured number falls inside the stated range.
By their numbers in this assay, from the lowest: compounds 4, 2, 3 and 1 (each within the scatter of the next, the first and the last beyond it).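

At this position, ortho to a fluoro group, the only exchange shown is chloro in place of bromo, and in this assay it gives a 1.8-fold lower number from compound 2 to compound 4 (0.26 log units; within the scatter) as its step. On the background of compound 2, the two halogens therefore cannot be told apart here, so this position joins the fluoro, chloro and nitro exchanges elsewhere in the molecule in showing no step beyond the scatter. Nothing measured here bears on the reason for the size of this step.

As far as these compounds go, whether a methoxy group, a nitrile or an amine at this position would give a step beyond the scatter remains open. From the compounds shown here alone, it is also open whether chloro in place of bromo reads the same with the fluoro of compound 1 or the nitro of compound 3 in place of the chloro of compound 2.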